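The source may hold more compounds than are shown below. What is called first, only, known or untested is meant among the compounds shown, and "the series" means these compounds.

Measured compounds: compound 1 `CCOC(=O)c1ccc(NC(=O)N2CC2C#N)cc1` gives 7700 nM; compound 2 `CCCCNC(=O)N1CC1C#N` gives 12000 nM; compound 3 `N#CC1CN1C(=O)Nc1ccc([N+](=O)[O-])cc1` gives 6500 nM.

In a functional assay on OVCAR-3 cells (Homo sapiens) for inhibition (a higher number here means a weaker inhibitor, a lower number a stronger inhibitor), compound 2 gives a number whose gaps to compound 1 and to compound 3 both fall within the scatter, so the three sit together. Compound 4 `CCNC(=O)N1CC1C#N` differs from compound 2 by hydrogen in place of ethyl on a saturated chain carbon, two bonds along the chain from an amide-type nitrogen. Going by the values given here, the only measured step, a 1.2-fold lower number from compound 1 to compound 3 (0.07 log units; within the scatter), alters an aromatic substituent and was within the scatter; no measured pair shortens the chain on the urea nitrogen, so nothing bears directly on this change. Compound 4 is therefore expected to stay near compound 2, a step of a 1.3-fold higher number from compound 2 to compound 4 (0.10 log units; within the scatter) in this assay. The estimate for compound 4 is 15000 nM, with a range from 6000 nM to 40000 nM.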

Compound 4, half-maximal inhibitory concentration: 14000 nM
Estimate against measurement, compound 4: 1.1-fold (0.03 log units) above; the measured number falls inside the stated range.
By their numbers in this assay, from the lowest: compounds 3, 1, 2 and 4 (each within the scatter of the next, the first and the last beyond it).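

In this assay the butyl to ethyl change on the chain gives a 1.2-fold higher number from compound 2 to compound 4 (0.07 log units; within the scatter), the first measured step at this position, where the earlier compounds had shown only a change on an aromatic carbon. Across this one change, then, removing the outer ethyl leaves the number inside the scatter, so the two chain lengths cannot be told apart here. Nothing available explains this result. Still open, going by these compounds, is whether a much longer chain such as octyl, or an amine or a carboxylic acid at the chain end, would also leave the number unchanged in this assay.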